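The source may hold more compounds than are shown below. What is called first, only, known or untested is meant among the compounds shown, and "the series" means these compounds.

Three ureas sharing one core were examined in an ADME assay on the whole organism with Oryza sativa as the target, tested at 10 uM; on this read-out lower numbers stand for a stronger effect and higher numbers for a weaker effect at the one concentration tested. Compound 1, `CCc1cccc(NC(=O)N[C@@H](C)c2ccccc2)c1`, gives 86% in this assay. Compound 2, `C[C@H](NC(=O)Nc1cccc(C(F)(F)F)c1)c1ccccc1`, gives 92%. Compound 3, `CC(=O)c1cccc(NC(=O)N[C@@H](C)c2ccccc2)c1`, gives 94%. On these three numbers compound 2 sits between compound 1 and compound 3, with compound 3 nearest and compound 1 furthest, all three within the scatter of one another. The steps among them are small: a number 6 percentage points higher from compound 1 to compound 2 (within the scatter), a number 8 percentage points higher from compound 1 to compound 3 (within the scatter) and a number 2 percentage points higher from compound 2 to compound 3 (within the scatter), none of them beyond the scatter, so the three compounds cannot be separated on this read-out.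

Compound 4, `C[C@H](NC(=O)Nc1cc(C(F)(F)F)cc(C(F)(F)F)c1)c1ccccc1`, has not yet been measured. It differs from compound 2 in one place: trifluoromethyl in place of hydrogen on an aromatic carbon. Going by the values given here, no measured step involves a second trifluoromethyl group, so the only guidance comes from the three steps described, each of which exchanges one group on an aromatic carbon of that ring without moving the number beyond the scatter. Compound 4 is therefore expected to stay close to compound 2. For compound 4 the expected step is a number 2 percentage points lower from compound 2 to compound 4 (within the scatter), which is none beyond the scatter. The estimate for compound 4 in this assay is 90%, within a range from 76% to 100%.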

Compound 4, a percentage reported as activity, at one concentration (the size of the read-out at that concentration, not a potency): 86%
Compound 4: the middle estimate sits 4 percentage points above what was measured, within the range that was stated.
By their numbers in this assay, from the lowest: compounds 1, 4, 2 and 3 (each within the scatter of the next).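

Going by these compounds alone, the move to compound 4 is the first change at this position of the ring, an aromatic carbon meta to a large group and meta to a trifluoromethyl group, where every earlier compound carries hydrogen. In this assay, within the data shown here, the exchange of that hydrogen for trifluoromethyl, which brings in 4 heavy atoms, gives a number 6 percentage points lower from compound 2 to compound 4 (within the scatter) and so leaves compound 4 inseparable from compound 2 on this read-out, which shows that this second position, like the one varied among the earlier compounds, takes a new group without a step beyond the scatter. No measurement shown here bears on why the number for compound 4 falls where it does.

Among these compounds, what remains open is whether another kind of group at this position, such as an amine, a carboxylic acid or a longer chain, would give a step beyond the scatter, since trifluoromethyl is the only group seen there. Also open, going by these compounds, is whether trifluoromethyl at this position would behave the same way with ethyl or acetyl at the other position of the ring, as in compound 1 and compound 3, rather than a second trifluoromethyl group.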